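This account rests on a few compounds, and the source may have more. Where it says the series, first, only, none or still open, it means among the compounds named here.

Working notes on the triazolopyrimidine-type series as it stands.

Compound 1 `CCC(COC)N(C)c1nc(C)nc2c1nnn2-c1ccc(C(C)C)cc1Br` and compound 2 `CCCCN(CC)c1nc(C)nc2c1nnn2-c1c(C)cc(C)cc1C` share the core and have both been measured in an in vitro assay on 293-EBNA cells for binding affinity to corticotropin-releasing factor receptor 1 (Homo sapiens); on this read-out lower numbers stand for stronger inhibition and higher numbers for weaker inhibition. In this assay compound 1 gives 11.2 nM, and in this assay compound 2 gives 27.5 nM. Going by the values given here, of the two numbers so far, compound 2 has the higher one; its nearest neighbour is compound 1, whose number is lower by an amount beyond the usual scatter. The two compounds differ in more than one place, so nothing is counted as a single step between them; their values simply show compound 2 as the weaker binder of the pair.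

The next compound, compound 3 `COCCNc1nc(C)nc2c1nnn2-c1c(C)cc(C)cc1C`, is derived from compound 2 by one change: (2-methoxyethyl)amino in place of butyl(ethyl)amino on an aromatic carbon. Among the compounds with values here, no measured pair isolates this change, so its effect is not known from the data. The expectation is a moderate loss, with the step from compound 2 to compound 3 estimated at a 2.9-fold higher number from compound 2 to compound 3 (0.46 log units; beyond the scatter) in this assay. Compound 3 is accordingly expected to give about 80 nM in this assay, within a range from 25 nM to 250 nM.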

Compound 3, inhibition constant: 1200 nM
Compound 3: the middle estimate sits 15-fold (1.18 log units) below what was measured, outside the stated range (above it).
By their numbers in this assay, from the lowest: compound 1; then compound 2; then compound 3.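

In this assay, going by these compounds alone, the group on this aromatic carbon, next to the ring nitrogen and ortho to a fused ring, proves to have a strong influence on the read-out: (2-methoxyethyl)amino in place of butyl(ethyl)amino gives a 44-fold higher number from compound 2 to compound 3 (1.64 log units; beyond the scatter), and this is the only pair that isolates a change at this position. Within the data shown here, the single change alters several things at once, going from 7 heavy atoms with 0 hydrogen-bond donors and 1 hydrogen-bond acceptor to 5 heavy atoms with 1 hydrogen-bond donor and 2 hydrogen-bond acceptors, and replacing a carbon-only chain set with one that contains an oxygen. Nothing measured for the series explains the size of this step.

Which of these differences carries the step stays open, and groups such as butylamino, N-ethyl-N-(2-methoxyethyl)amino or bis(2-methoxyethyl)amino at the same carbon would help separate the amine hydrogen from the ether oxygen and the chain length. On these data alone, it is also open whether (2-methoxyethyl)amino would have a step of similar size on the core of compound 1, with its bromine and isopropyl-bearing aryl ring.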